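A few compounds are considered here, and "the series" means these few. Any claim that something is new, unique, unknown or untested is made for them only; others in the source may bear on it.

Measured in a functional assay on IC8 cells (Homo sapiens) for antiproliferative activity, read by MTT assay, with a stated time of 72 h; a higher number here means a weaker inhibitor, a lower number a stronger inhibitor:
- compound 1 `COc1cc(/C=C\c2cc3ccccc3s2)cc(OC)c1OC`: 17 nM
- compound 2 `COc1cc(/C=C/c2cc3ccccc3s2)cc(OC)c1OC`: "not determined" (no result reported)
- compound 3 `COc1cc(/C=C\c2ccsc2)cc(OC)c1OC`: "not determined" (no result reported)

Only compound 1 has a number here. One feature of this series is the fact that compounds 1 and 2 differ only in the configuration as drawn, but without a number for compound 2, that pair shows nothing about activity. For the measured compounds named here, compound 3 has no number of its own, so its place on the scale is unknown, and the only reference point is compound 1 at 17 nM.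

Still to be measured is compound 4 `COc1csc(/C=C\c2cc(OC)c(OC)c(OC)c2)c1`. The structural change is 4-methoxythiophen-2-yl in place of thiophen-3-yl on a double-bonded chain carbon bound to a double-bonded chain carbon.

Going by the values given here, no measured step guides this change, and with no starting number its size in this assay can only be judged loosely. The expectation is a step towards stronger inhibition, but the evidence for this is thin, so the range must stay wide.

Compound 4 is expected at about 60 nM, with an estimated range of 10 nM to 400 nM.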

Compound 4, half-maximal inhibitory concentration: 27 nM
Beside the measured number, compound 4's estimate is 2.2-fold (0.35 log units) above it, within the range that was stated.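

In this assay compound 4 gives 27 nM, but compound 3 has no number, so the step from compound 3 to compound 4 cannot be read. Going by these compounds, how 4-methoxythiophen-2-yl compares with thiophen-3-yl in activity stays open. Nothing shown here bears on this result.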